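Compound 4 against a ceiling of limits

The compounds below may be only part of what the source reports. "The series", "measured", "known", "first", "only" and "open" are said of these compounds alone.

- Compound 1 `COc1ccc(-c2cnc(NC(=O)c3ccccc3O)n2C)cc1`: > 100000 nM
- Compound 2 `COc1ccc(-c2cnc(NC(=O)c3cccc(OC)c3)n2C)cc1`: > 100000 nM
- Compound 3 `COc1ccc(-c2cnc(NC(=O)c3ccccc3Br)n2C)cc1`: > 100000 nM

All three compounds were tested in a toxicity assay on THP-1 cells (Homo sapiens) for inhibition (on this read-out lower numbers stand for higher toxicity in this test and higher numbers for lower toxicity in this test), and each result is a limit of the assay rather than a number. In this assay compound 3 gives > 100000 nM, so it has no exact position in the series. It shares this position with the other two compounds: the limit of > 100000 nM in this assay, at which 3 of the 3 values shown sit.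

The next compound, compound 4 `COc1ccc(-c2cnc(NC(=O)c3ccc(C#N)cc3)n2C)cc1`, keeps the shared core and the amide but carries 4-cyanophenyl in place of 2-bromophenyl on a carbonyl carbon.

Going by the values given here, three measured steps bear on this change, since each alters the group on the carbonyl carbon. They are a step that the two limits leave unreadable from compound 1 to compound 2, a step that the two limits leave unreadable from compound 1 to compound 3 and a step that the two limits leave unreadable from compound 2 to compound 3. Among the compounds with values here, the last is the closest precedent, as it also replaces the 2-bromophenyl partner, but none of the three has a readable size. They show no toxicity within the tested range for these three compounds, and they give no direction for compound 4. No step beyond the usual scatter is therefore expected in this assay, and another limit is the likeliest report.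

The expected result is a number no higher from compound 3 to compound 4 (the limit leaves the size open). For compound 4 the estimated value is 100000 nM, with an expected range from 40000 nM to 200000 nM.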

Compound 4, half-maximal cytotoxic concentration: > 100000 nM
Compound 4: a limit, no number; the forecaster's own chance of this, stated with the estimate: 85%; the middle value sits exactly at the limit.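

In this assay compound 4 gives > 100000 nM as a limit of the assay and not a number. No new step can be read from compound 1, compound 2 or compound 3 to compound 4, because all four compounds share one position: the limit of > 100000 nM in this assay, at which 4 of the 4 values shown sit.

The compounds shown leave open whether any group on the carbonyl carbon gives a measurable toxicity in this test.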